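The source may hold more compounds than are shown below. What is called first, only, known or untested is meant among the compounds shown, and "the series" means these compounds.

Measured compounds in an assay on cells for inhibition of Voltage-dependent T-type calcium channel subunit alpha-1H (Homo sapiens), read by FLIPR and calcium flux, with stated times of 600 s and 300 s; on this read-out higher numbers stand for weaker inhibition and lower numbers for stronger inhibition:
- compound 1 `CN(Cc1ccc(OCCCNC(=N)N)cc1)c1nc2ccc(Oc3cccc(C(F)(F)F)c3)cc2s1`: 771000 nM
- compound 2 `CN(Cc1ccc(OCCCN)cc1)c1nc2ccc(Oc3cccc(C(F)(F)F)c3)cc2s1`: 239000 nM
- compound 3 `NCCCOc1ccc(CNc2nc3ccc(Oc4ccc(C(F)(F)F)cc4)cc3s2)cc1`: 112000 nM

Compound 1 gives the highest of the three numbers, so the weakest inhibition; its nearest neighbour is compound 2, and compound 3 lies furthest from it. Among the compounds with values here, the one single-point step on hand, a 3.2-fold lower number from compound 1 to compound 2 (0.51 log units; beyond the scatter), concerns the amine end of the chain and not the aryl ether, and compound 3 differs from compound 1 in more than one place, so its value can only be read together with the other two.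

Compound 4 `CN(Cc1ccc(OCCCNC(=N)N)cc1)c1nc2ccc(Oc3ccc(O)cc3)cc2s1` changes the aryl ether of compound 1: 4-hydroxyphenyl in place of 3-(trifluoromethyl)phenyl on an oxygen on an aromatic ring. Within the data shown here, no measured step covers this change, so no direction can be drawn from the data; the expectation is therefore wide. Compound 4 is estimated at 1500000 nM, expected within 400000 nM to 5000000 nM, which means an expected step of a 1.9-fold higher number from compound 1 to compound 4 (0.29 log units; within the scatter).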

Compound 4, half-maximal inhibitory concentration: 332000 nM
For compound 4 the middle estimate is 4.5-fold (0.65 log units) above the measured one; the measured number lies below the stated range.
By their numbers in this assay, from the lowest: compound 3; then compounds 2 and 4 (each within the scatter of the next); then compound 1.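

The aryl ether position responds to substitution: on an oxygen on an aromatic ring, 4-hydroxyphenyl in place of 3-(trifluoromethyl)phenyl gives a 2.3-fold lower number from compound 1 to compound 4 (0.37 log units; beyond the scatter) in this assay. Within the data shown here, this is the first reading at this position, and it shows that the trifluoromethyl group is not needed to keep the number from rising in this guanidine-ended compound. No measurement on hand accounts for the shift. As far as these compounds go, whether the same exchange holds with the amine chain of compound 2 remains open. From the compounds shown here alone, how a methoxyphenyl or unsubstituted phenyl group would read at this position also remains open.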